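This account rests on a few compounds, and the source may have more. Where it says the series, first, only, none or still open, it means among the compounds named here.

Measured so far in a functional assay on MDA-MB-231 cells (Homo sapiens) for cytotoxicity, read by MTT assay, with a stated time of 48 h; on this read-out lower numbers stand for stronger inhibition and higher numbers for weaker inhibition:

compound 1 `COc1cc(-c2ocnc2-c2cc(OC)c(OC)c(OC)c2)ccc1SC` gives 850 nM.
compound 2 `COc1ccc(-c2ocnc2-c2cc(Br)c(OC)c(OC)c2)cc1OC` gives 7830 nM.
compound 3 `COc1ccc(-c2c(-c3cc(Br)c(OC)c(OC)c3)ncn2C)cc1SC` gives > 20000 nM, which is a limit of the assay and not a number.

Going by the values given here, of the two numbers read so far in this assay, compound 2 stands highest, meaning weakest inhibition; its nearest neighbour is compound 1, whose number is far lower, a gap beyond the usual scatter. Compound 1 and compound 2 differ in more than one place, so that gap cannot be pinned on any single group.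

Compound 4 `COc1ccc(-c2ocnc2-c2cc(Br)c(OC)c(OC)c2)cc1SC` has not yet been measured. It differs from compound 2 in one place: methylsulfanyl in place of methoxy on an aromatic carbon. Compound 1 carries this same methylsulfanyl group and reaches a much lower number than compound 2, but it also carries a different set of substituents on the other ring. Compound 3 carries methylsulfanyl on a different core and reached only a limit in this assay.

On this basis the step I expect in this assay is a 2.6-fold lower number from compound 2 to compound 4 (0.42 log units; beyond the scatter), a modest move toward a lower number, stronger inhibition, near the edge of the scatter. Compound 4 is therefore estimated at 3000 nM, with a likely range from 900 nM to 12000 nM.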

Compound 4, half-maximal inhibitory concentration: 920 nM
The estimate for compound 4 lay 3.3-fold (0.51 log units) above the measured number; the range from low to high includes it.
By their numbers in this assay, from the lowest: compounds 1 and 4 (each within the scatter of the next); then compound 2. At a limit, above all of these: compound 3.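

In this assay, putting methylsulfanyl in place of methoxy on this aromatic carbon, ortho to a methoxy group, gives an 8.5-fold lower number from compound 2 to compound 4 (0.93 log units; beyond the scatter). Going by these compounds alone, this is the first change in the set that can be read on its own, whereas compound 1 also carries methylsulfanyl but differs from compound 2 in more than one place, so its lower number could not be tied to any single group. The two groups have the same count of heavy atoms and of hydrogen-bond acceptors, so this large shift in cell potency comes with an exchange of oxygen for sulfur, though nothing measured here explains why the number moves.

From the compounds shown here alone, compound 3 carries the same methylsulfanyl on a different core and sits at a limit of the assay (> 20000 nM), so whether this step holds on any other core stays open. Also open, going by these compounds, is how this position would respond to other groups, such as an amine, a hydroxyl or a longer chain like ethylsulfanyl, since the compounds compared here hold only methoxy or methylsulfanyl at this place.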